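Amide variation on the shared core

The compounds below may be only part of what the source reports. "The series", "measured", "known", "first", "only" and "open" are said of these compounds alone.

Going by the values given here, compound 3 `N#Cc1cccc(C(=O)Nc2c(C(O)(C(F)(F)F)C(F)(F)F)ccc3ccccc23)c1` gives 12 nM in an assay on LtK cells with ATP-sensitive inward rectifier potassium channel 11 (Homo sapiens) as the target (a lower number here means that less compound is needed, a higher number that more compound is needed for the effect), the lowest of the three numbers measured so far. Compound 2 `O=C(Nc1c(C(O)(C(F)(F)F)C(F)(F)F)ccc2ccccc12)c1cccc(Br)c1` gives 80 nM and compound 1 `CC(C)C(=O)Nc1c(C(O)(C(F)(F)F)C(F)(F)F)ccc2ccccc12` gives 6630 nM. Compound 4 `O=C(Nc1c(C(O)(C(F)(F)F)C(F)(F)F)ccc2ccccc12)c1ccc(OC(F)(F)F)cc1` differs from compound 3 by 4-(trifluoromethoxy)phenyl in place of 3-cyanophenyl on a carbonyl carbon. The measured steps that bear on this are a 550-fold lower number from compound 1 to compound 3 (2.74 log units; beyond the scatter) and an 83-fold lower number from compound 1 to compound 2 (1.92 log units; beyond the scatter), both showing an aromatic ring on the carbonyl carbon giving a far lower number than isopropyl, and a 6.7-fold lower number from compound 2 to compound 3 (0.82 log units; beyond the scatter), a modest change between two ring substituents. Compound 4 keeps an aromatic ring, so a number near those of compound 2 and compound 3 is expected, though nothing measured speaks to the trifluoromethoxy group itself. The estimate for compound 4 is 60 nM with a range of 15 nM to 250 nM. This means a step of a 5.0-fold higher number from compound 3 to compound 4 (0.70 log units; beyond the scatter) is expected.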

Compound 4, half-maximal effective concentration: > 10000 nM
Compound 4 ended at the assay's limit; the forecaster's own chance of this, stated with the estimate: 3%; middle value at least 160-fold (2.22 log units) away from the limit.
By their numbers in this assay, from the lowest: compound 3; then compound 2; then compound 1. At a limit, above all of these: compound 4.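

An aromatic ring on the carbonyl carbon does not by itself keep the number low: the series shows an at least 830-fold higher number from compound 3 to compound 4 (2.92 log units; beyond the scatter), an at least 120-fold higher number from compound 2 to compound 4 (2.09 log units; beyond the scatter) and an at least 1.5-fold higher number from compound 1 to compound 4 (0.17 log units; that floor lies within the scatter). Going by these compounds alone, compound 4 sits at an assay limit, not at a number: the limit of > 10000 nM in this assay, at which 1 of the 4 values shown sits. Of the three steps, only the one starting from compound 1 has a floor within the scatter.

The compounds shown do not separate the trifluoromethoxy group itself from the different substitution pattern of 4-(trifluoromethoxy)phenyl compared with 3-cyanophenyl and 3-bromophenyl. As far as these compounds go, how an amine or a carboxylic acid on this aromatic ring would read also stays open.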